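Replacing the benzyloxy arm of compound 1

This account rests on a few compounds, and the source may have more. Where it says the series, first, only, none or still open, it means among the compounds named here.

Among the compounds with values here, compound 1 `Clc1ccc2[nH]c(SCc3ccccc3OCc3ccccc3)nc2c1` sits lowest of the three measured members. In an assay on isolated protein for inhibition of Indoleamine 2,3-dioxygenase 1 (Homo sapiens), with a stated time of 60 min, tested at 10 uM (on this read-out higher numbers stand for more inhibition at the one concentration tested (going by the name of the read-out) and lower numbers for less inhibition), compound 1 gives 3%. Compound 2 `c1ccc(CCc2ccccc2CSc2ncc[nH]2)cc1` gives 19% in this assay, and compound 3 `c1ccc(CCc2ccccc2CSc2nc3ccccc3[nH]2)cc1` gives 43%; both stand beyond the scatter above compound 1. Compound 4 `[O-][S+](Cc1ccccc1)c1ccccc1CSc1nc2cc(Cl)ccc2[nH]1` keeps the core of compound 1 and alters one arm: a group of 9 heavy atoms (7 carbon, 1 oxygen, 1 sulfur; one six-membered aromatic ring of carbon only) in place of a group of 8 heavy atoms (7 carbon, 1 oxygen; one six-membered aromatic ring of carbon only), on an aromatic carbon. Within the data shown here, no measured pair shows this change, so its size is open. Because compound 1 gives only 3% while the entering group keeps one hydrogen-bond acceptor and one six-membered aromatic ring of carbon only, a small upward step for compound 4 is expected, a number 9 percentage points higher from compound 1 to compound 4 (within the scatter), probably within the scatter. Compound 4 is estimated at 12%, in the range 0% to 35%.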

Compound 4, a percentage reported as inhibition, at one concentration (the size of the read-out at that concentration, not a potency): 11%
Compound 4: the middle estimate sits 1 percentage points above what was measured; the measured number falls inside the stated range.
By their numbers in this assay, from the lowest: compounds 1, 4 and 2 (each within the scatter of the next, the first and the last beyond it); then compound 3.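

Exchanging the benzyloxy arm for the group of 9 heavy atoms on this aromatic carbon gives a number 8 percentage points higher from compound 1 to compound 4 (within the scatter), so this position accepts the exchange with the read-out staying within the scatter. Both arms have one six-membered aromatic ring of carbon only and one hydrogen-bond acceptor, and the entering group adds a sulfur. No data bearing on the cause of this result are available.

Open, from the compounds shown here alone, is how an arm ending in an amine or a carboxylic acid would read at this position. Going by these compounds, a longer chain between the sulfur and the aromatic ring also remains untested in these compounds.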